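A few compounds are considered here, and "the series" means these few. Any claim that something is new, unique, unknown or untested is made for them only; others in the source may bear on it.

The measured compounds in an assay on isolated protein for inhibition of Dihydrofolate reductase (Mus musculus); on this read-out higher numbers stand for higher potency (the scale is a negative logarithm) and lower numbers for lower potency:
compound 1, `CC1(C)N=C(N)N=C(N)N1c1ccc(OCc2ccc(Cl)cc2S(=O)(=O)F)c(Cl)c1`, giving 7.52;
compound 2, `CC1(C)N=C(N)N=C(N)N1c1cccc(CCCCc2cccc(S(=O)(=O)F)c2)c1`, giving 8.1;
compound 3, `CC1(C)N=C(N)N=C(N)N1c1ccc(OCc2ccc(C(=O)Nc3cccc(S(=O)(=O)F)c3)cc2)c(Cl)c1`, giving 7.41.

Compound 1 stands second highest of these three numbers. Compound 3 lies closest to it, a gap within the usual scatter of repeated measurements, so no order between compound 1 and compound 3 can be read from these two numbers. Compound 2 lies furthest from compound 1, beyond the scatter, and carries the higher number.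

The unmeasured compound 4, `CC1(C)N=C(N)N=C(N)N1c1ccc(OCc2ccccc2S(=O)(=O)F)c(Cl)c1`, differs from compound 1 in one place: hydrogen in place of chloro on an aromatic carbon. No comparable change between two measured compounds exists here, so the step has to be judged from the change alone. The step from compound 1 to compound 4 is expected to be small, slightly downward, and not beyond the scatter: a number 0.22 log units lower from compound 1 to compound 4 (within the scatter). In this assay compound 4 is expected to give 7.3, estimated to lie between 6.7 and 7.9.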

Compound 4, logarithm of the reciprocal of the active concentration, log(1/C): 7.43
Compound 4: middle estimate off by 0.13 log units, on the low side, within the range that was stated.
By their numbers in this assay, from the lowest: compounds 3, 4 and 1 (each within the scatter of the next); then compound 2.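

In this assay hydrogen in place of chloro on this aromatic carbon, meta to a fluorosulfonyl group and para to a large group, gives a number 0.09 log units lower from compound 1 to compound 4 (within the scatter) and so shows that the two numbers cannot be told apart without this chloro. The earlier compounds shown here offered no such one-place pair. Nothing available here bears on the reason for this.

On these data alone, whether a methoxy group, an amine or a carboxylic acid on this carbon would also stay within the scatter remains open. So does the effect of changing the chloro that compound 4 keeps.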